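From Methoxy to Propoxy Against an Assay Limit

A few compounds are considered here, and "the series" means these few. Any claim that something is new, unique, unknown or untested is made for them only; others in the source may bear on it.

In an ADME assay on KB cells (Homo sapiens) for cytotoxicity (on this read-out higher numbers stand for an effect only at larger amounts of compound and lower numbers for an effect already at smaller amounts), compound 2 `COc1cc2c(c(OC)c1OC)C(=O)[C@]1(OC)C=C[C@H]2N(C(=O)OCC(C)C)N1C(=O)OCC(C)C` gives > 300 ug/mL, which is a limit of the assay and not a number. Its true position is therefore unknown, and the same applies to much of this small set, as the limit of > 300 ug/mL in this assay, at which 2 of the 3 values shown sit, shows. Only compound 1 `CCOC(=O)N1[C@@H]2C=C[C@@](OC)(C(=O)c3c2cc(OC)c(OC)c3OCc2ccc(F)cc2)N1C(=O)OCC` gives an actual number, 51.8 ug/mL.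

Compound 4 `CCCOc1c(OC)c(OC)cc2c1C(=O)[C@]1(OC)C=C[C@H]2N(C(=O)OCC(C)C)N1C(=O)OCC(C)C` differs from compound 2 in one place: ethyl in place of hydrogen on a saturated chain carbon bound to an oxygen on an aromatic ring. An ethyl takes the place of a hydrogen on a saturated chain carbon bound to an oxygen on an aromatic ring, turning methoxy into propoxy. Going by the values given here, no measured pair shows this change alone, so any forecast is loose. Compound 3 `CCCCOc1c(OC)c(OC)cc2c1C(=O)[C@]1(OC)C=C[C@H]2N(C(=O)OC)N1C(=O)OC`, which carries a butoxy group, also gives a limit, > 300 ug/mL, so a large move toward smaller amounts is not expected for compound 4. No step beyond the scatter is expected in this assay, and the estimated change is an at least 1.2-fold lower number from compound 2 to compound 4 (0.07 log units; that floor lies within the scatter). For compound 4 the estimated value is 250 ug/mL, with an expected range from 80 ug/mL to 500 ug/mL.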

Compound 4, concentration for half-maximal effect: 299 ug/mL
Compound 4: the middle estimate sits 1.2-fold (0.08 log units) below what was measured, within the range that was stated.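

Compound 2 gives > 300 ug/mL in this assay, which is a limit of the assay and not a number. Compound 4, with propoxy in place of methoxy, gives 299 ug/mL, so this position on the shared core now carries a true number, and even with the added ethyl an effect appears only at large amounts of compound. The change from methoxy to propoxy gives a number no higher from compound 2 to compound 4 (the limit leaves the size open), and the same limit still marks much of the set: the limit of > 300 ug/mL in this assay, at which 2 of the 4 values shown sit.

The compounds shown leave open how far the true value of compound 2 lies from that of compound 4. They also leave open what an amine or a carboxylic acid at the end of this chain would do to the value.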